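The source may hold more compounds than are shown below. What is called first, only, known or untested is meant among the compounds shown, and "the series" means these compounds.

Among the compounds with values here, compound 1 `COc1cc(OC)c2c(=O)cc(C3(O)C=CC(=O)C=C3)oc2c1` is one of three compounds measured in a functional assay on A549 cells (Homo sapiens) for cytotoxicity, read by colorimetric assay and MTT assay, with a stated time of 72 h (on this read-out higher numbers stand for weaker inhibition and lower numbers for stronger inhibition), where compound 1 gives 1270 nM. Compound 2 `COc1cc(OC)c2c(=O)cc(C3(OC)C=CC(=O)C=C3)oc2c1` differs from compound 1 by methyl in place of hydrogen on an oxygen on a saturated carbon. In this assay compound 2 reaches only a limit of the assay, > 60900 nM. That change therefore produced an at least 47-fold higher number from compound 1 to compound 2 (1.68 log units; beyond the scatter), a step whose true size is hidden by the limit (the limit of > 60900 nM in this assay, at which 1 of the 3 values shown sits). Compound 3 `O=C1C=CC(O)(c2cc(=O)c3c(O)cccc3o2)C=C1` has a different core; the difference between the two cores is not broken down here. In this assay compound 3 gives 5070 nM. Compound 4 `COC1(c2cc(=O)c3c(O)cccc3o2)C=CC(=O)C=C1` has not been measured and differs from compound 3 by methyl in place of hydrogen on an oxygen on a saturated carbon, the same change as from compound 1 to compound 2. By analogy to an at least 47-fold higher number from compound 1 to compound 2 (1.68 log units; beyond the scatter), a step of a 30-fold higher number from compound 3 to compound 4 (1.47 log units; beyond the scatter) is expected for compound 4. Compound 4 is therefore estimated to reach about 150000 nM in this assay, quite possibly only as a limit.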

Compound 4, half-maximal inhibitory concentration: 57600 nM
Estimate against measurement, compound 4: 2.6-fold (0.42 log units) above; low and high end bracket the measured number.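

In this assay, methyl in place of hydrogen on the oxygen again weakens the result on the core of compound 3, with an 11-fold higher number from compound 3 to compound 4 (1.06 log units; beyond the scatter). The direction of the change therefore carries over from the core of compound 1 to the core of compound 3, but its size does not carry over unchanged: the same change on two cores in this assay, an at least 47-fold higher number (1.68 log units; beyond the scatter) from compound 1 to compound 2 and an 11-fold higher number (1.06 log units; beyond the scatter) from compound 3 to compound 4, at least 4.2-fold (0.62 log units) apart, beyond the scatter of two such steps. On these data alone, compound 2 sits at a limit of the assay, so the true gap between the two steps stays unknown: the limit of > 60900 nM in this assay, at which 1 of the 4 values shown sits.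

The compounds shown hold only hydroxy or methoxy at this place, so it stays open how an ethoxy group or an amine would read there. As far as these compounds go, whether the direction of the change also holds on a third core stays open as well.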